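Notes on the step from compound 2 to compound 4

The source may hold more compounds than are shown below. What is called first, only, known or untested is meant among the compounds shown, and "the series" means these compounds.

Values in a functional assay on A549 cells (Homo sapiens) for antiproliferative activity, read by MTT assay, with a stated time of 72 h (a lower number here means a stronger inhibitor, a higher number a weaker inhibitor), are as follows:
- Compound 1 `CC(C)(C)c1ccc(OCCCON2C(N)=NC(N)=NC23CCSCC3)cc1` gives 1 nM
- Compound 2 `NC1=NC2(CCSCC2)N(OCCCOc2ccc(Br)cc2)C(N)=N1` gives 740 nM
- Compound 3 `NC1=NC2(CCOCC2)N(OCCCOc2ccccc2Cl)C(N)=N1` gives 2700 nM

Compound 2 stands in the middle of these three values, with compound 1 lower and compound 3 higher. Compound 4 `NC1=NC2(CCSCC2)N(OCCCOc2ccccc2Cl)C(N)=N1` differs from it as follows: 2-chlorophenyl in place of 4-bromophenyl on an oxygen on a saturated carbon in words, 2-chlorophenyl in place of 4-bromophenyl on an oxygen on a saturated carbon. Going by the values given here, the one measured step on a substituent of this aromatic ring is a 740-fold higher number from compound 1 to compound 2 (2.87 log units; beyond the scatter) and it is large, so a sizeable move cannot be excluded. Compound 3 carries the same 2-chlorophenyl on a different core and gives 2700 nM in this assay so a modest rise is expected. The expected change is a 1.8-fold higher number from compound 2 to compound 4 (0.24 log units; within the scatter) and remains uncertain. In this assay compound 4 is estimated at 1300 nM with 300 nM to 5000 nM as the expected range.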

Compound 4, half-maximal inhibitory concentration: 80 nM
Estimate against measurement, compound 4: 16-fold (1.21 log units) above; measured number outside the range, below it.
By their numbers in this assay, from the lowest: compound 1; then compound 4; then compound 2; then compound 3.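

In this assay, going by these compounds alone, the halogenated aryl ether can change the number in either direction on this core: a 9.3-fold lower number from compound 2 to compound 4 (0.97 log units; beyond the scatter) is a fall, whereas the one earlier step here was a rise. Compound 4 gives 80 nM while compound 3, with the same 2-chlorophenyl on a different core, gives 2700 nM, so that group's value does not carry across cores. Nothing available explains the step.

From the compounds shown here alone, the step changes both the halogen and the group's numbering, leaving their shares unseparated. 2-Bromophenyl and 4-chlorophenyl on this core remain open.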